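A few compounds are considered here, and "the series" means these few. Any claim that something is new, unique, unknown or untested is made for them only; others in the source may bear on it.

Working notes on the series. Compound 1 `C=CCNC(=O)n1c(-c2ccc(OC)cc2)cc(=O)c2c(OC)cc(OC)cc21` carries allylcarbamoyl on the aromatic nitrogen of the shared core, and in an ADME assay on BJ cells (Homo sapiens) for antiproliferative activity, with a stated time of 72 h (a lower number here means that less compound is needed, a higher number that more compound is needed for the effect), compound 1 gives 74000 nM. Compound 2 `COc1ccc(-c2cc(=O)c3c(OC)cc(OC)cc3n2S(=O)(=O)c2cc(Cl)cc(Cl)c2O)cc1` bears (3,5-dichloro-2-hydroxyphenyl)sulfonyl at that nitrogen. In this assay compound 2 returns only a limit, > 37900 nM, recorded as the limit of > 37900 nM in this assay, at which 1 of the 3 values shown sits. Compound 3 `COc1ccc(-c2cc(=O)c3c(OC)cc(OC)cc3n2S(=O)(=O)c2ccc(OC)cc2)cc1` carries (4-methoxyphenyl)sulfonyl at the same nitrogen. In this assay compound 3 likewise returns only a limit, > 82700 nM, recorded as the limit of > 82700 nM in this assay, at which 1 of the 3 values shown sits. Compound 3 therefore stands at the weak end of what the numbers can show. The step of an at least 1.1-fold higher number from compound 1 to compound 3 (0.04 log units; that floor lies within the scatter) has a floor that lies within the scatter, and the step that the two limits leave unreadable from compound 2 to compound 3 cannot be read from its two limits. Compound 4 `COc1ccc(-c2cc(=O)c3c(OC)cc(OC)cc3n2S(=O)(=O)Cc2ccccc2)cc1` is not yet measured and differs from compound 3 by benzyl in place of 4-methoxyphenyl on a sulfonyl sulfur. Neither measured step around compound 3 gives a readable size, so no step beyond the scatter is expected from this change. Compound 4 is expected to give about 80000 nM in this assay, within 30000 nM to 200000 nM. The expected step, an at least 1.0-fold lower number from compound 3 to compound 4 (0.01 log units; that floor lies within the scatter), is small, with a limit rather than a number the likelier outcome.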

Compound 4, half-maximal effective concentration: > 34400 nM
Compound 4 was reported as a limit (the forecaster's own chance of this, stated with the estimate: 65%); the middle value lies beyond the limit too.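

In this assay compound 4 returns only a limit, and its steps to compound 1, compound 2 and compound 3 cannot be read. The compounds shown leave open whether the sulfonyl groups at the aromatic nitrogen differ from one another, or from allylcarbamoyl, in antiproliferative effect.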